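Open-Chain Diol Replaces a Sugar on the Triazole Nitrogen

This account rests on a few compounds, and the source may have more. Where it says the series, first, only, none or still open, it means among the compounds named here.

Of the compounds shown here, three built on one shared core have been measured in a toxicity assay on L02 cells (Homo sapiens) for cytotoxicity, read by MTT assay, with a stated time of 72 h; on this read-out higher numbers stand for weaker inhibition and lower numbers for stronger inhibition. Compound 1 `CN1CCN(CCCCCCn2c3c(c4ccccc42)C(=O)c2c[n+]([O-])c4ccccc4c2C3=O)CC1` gives 3800 nM. Compound 2 `O=C1c2c[n+]([O-])c3ccccc3c2C(=O)c2c1c1ccccc1n2Cc1cn([C@H]2C[C@H](O)[C@@H](CO)O2)nn1` gives 280 nM, and compound 3 `CC1(C)OCC(Cn2cc(Cn3c4c(c5ccccc53)C(=O)c3c[n+]([O-])c5ccccc5c3C4=O)nn2)O1` gives 120 nM. Of these three numbers compound 2 holds the second highest; compound 3 is its nearest neighbour and compound 1 lies furthest from it. For the measured compounds named here, the only single-site step measured so far runs a 2.3-fold lower number from compound 2 to compound 3 (0.37 log units; beyond the scatter).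

Compound 4 `O=C1c2c[n+]([O-])c3ccccc3c2C(=O)c2c1c1ccccc1n2Cc1cn(CC(O)CO)nn1` is the next analogue and differs from compound 2 in one place: 2,3-dihydroxypropyl in place of 4-hydroxy-5-(hydroxymethyl)oxolan-2-yl on an aromatic nitrogen. The entering 2,3-dihydroxypropyl group is the ring-opened counterpart of the group carried by compound 3, so the step from compound 2 to compound 3 is the one that bears on this change, and it was modest though beyond the scatter. A step of similar or smaller size, downward or none beyond the scatter, is therefore expected in this assay. The step expected here is a 1.3-fold lower number from compound 2 to compound 4 (0.10 log units; within the scatter). For compound 4 the estimate in this assay is 220 nM, with a range from 90 nM to 550 nM.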

Compound 4, half-maximal inhibitory concentration: 1070 nM
The estimate for compound 4 lay 4.9-fold (0.69 log units) below the measured number; the measured number lies above the stated range.
By their numbers in this assay, from the lowest: compound 3; then compound 2; then compound 4; then compound 1.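

In this assay, for the compounds shown here, replacing the 4-hydroxy-5-(hydroxymethyl)oxolan-2-yl ring with the open 2,3-dihydroxypropyl chain gives a 3.8-fold higher number from compound 2 to compound 4 (0.58 log units; beyond the scatter), so this nitrogen substituent can also move the number upward, against the direction of the one earlier step. The free diol also stands apart from its 2,2-dimethyl-1,3-dioxolan-4-yl counterpart, with 1,2-dihydroxyethyl in place of that ring giving an 8.9-fold higher number from compound 3 to compound 4 (0.95 log units; beyond the scatter), while the larger replacement of the 5-(4-methylpiperazin-1-yl)pentyl group still gives a 3.6-fold lower number from compound 1 to compound 4 (0.55 log units; beyond the scatter). No measurement shown here accounts for these differences.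

The compounds shown leave open how a 3-hydroxypropyl chain, with one hydroxyl group, or a 2,3-dimethoxypropyl chain would compare at this position. They also leave open what a primary amine or a carboxylic acid at the end of the chain would do to the number.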